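This account rests on a few compounds, and the source may have more. Where it says the series, first, only, none or still open, it means among the compounds named here.

Compound 1 `COc1cc(/C=N/Nc2nc(-c3cccc(Br)c3)cs2)cc(Br)c1OC` gives 43400 nM in a functional assay on Caco-2 cells (Homo sapiens) for inhibition, read by MTT assay, with a stated time of 48 h; a higher number here means a weaker inhibitor, a lower number a stronger inhibitor.
Compound 3 `COc1cc(/C=N/Nc2nc(-c3ccccc3)cs2)cc(Br)c1OC` gives 64200 nM in this assay.
Compound 2 `COc1cc(/C=N/Nc2nc(-c3cc(C(F)(F)F)cc(C(F)(F)F)c3)cs2)cc(Br)c1OC` stands only at a limit of this assay, > 100000 nM.

The three measured compounds share a core, and the difference between the core of compound 2 and the core of compound 3 is not broken down here. Compound 3 and compound 1 differ in one place, (bromo in place of hydrogen on an aromatic carbon), and that change gave a 1.5-fold lower number from compound 3 to compound 1 (0.17 log units; within the scatter). For compound 2 the assay gives only (the limit of > 100000 nM in this assay, at which 1 of the 3 values shown sits), so no number is known for it, and the strength of compound 2 against compound 1 and compound 3 cannot be ranked beyond that.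

The unmeasured compound 4 `COc1cc(/C=N/Nc2nc(-c3cc(C(F)(F)F)cc(C(F)(F)F)c3)cs2)c(Br)c(Br)c1OC` differs from compound 2 by bromo in place of hydrogen on an aromatic carbon. Within the data shown here, this is the same kind of change as the one from compound 3 to compound 1, but its place is not the same: here the incoming bromo sits ortho to a bromo group, ortho to a large group, meta to a methoxy group and para to a methoxy group, whereas in the earlier pair it sat meta to a large group. Since the earlier step, a 1.5-fold lower number from compound 3 to compound 1 (0.17 log units; within the scatter), lay within the scatter, compound 4 is expected to sit close to where compound 2 sits, so a step that the limit leaves unreadable from compound 2 to compound 4 is estimated, and the result for compound 4 is expected to be around 120000 nM, within 50000 nM to 300000 nM, with a real chance that the assay again reports only a limit.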

Compound 4, half-maximal inhibitory concentration: > 100000 nM
Compound 4: no number, only a limit (the forecaster's own chance of this, stated with the estimate: 70%); the middle value lies beyond the limit too.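

In this assay compound 4 gives > 100000 nM, which is a limit and not a number. Compound 2 stands at a limit as well, so no step from compound 2 to compound 4 can be read: the limit of > 100000 nM in this assay, at which 2 of the 4 values shown sit.

The compounds shown leave open how strong compound 2 and compound 4 really are, and whether bromo in place of hydrogen changes anything in this pair.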